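A few compounds are considered here, and "the series" means these few. Any claim that something is new, unique, unknown or untested is made for them only; others in the source may bear on it.

Of the compounds shown here, two of this set have been tested in a functional assay on the whole organism (strain Sprague-Dawley) for inhibition, with Rattus norvegicus as the target (on this read-out lower numbers stand for an effect already at smaller amounts and higher numbers for an effect only at larger amounts of compound), and both gave only a limit of the test rather than a number. Compound 1, `CCCCc1ccc2ncc(-c3nn[nH]n3)cc2c1`, reached in this assay the limit > 25 mg/kg. Compound 2, `COc1ccc2c(O)c(C(=O)O)cnc2c1`, reached in this assay the limit > 100 mg/kg. Since the two results shown are the limit of > 100 mg/kg in this assay, at which 1 of the 2 values shown sits, and (the limit of > 25 mg/kg in this assay, at which 1 of the 2 values shown sits), compound 1 cannot be ranked against compound 2; its standing is simply that no effect was seen up to its own limit.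

Compound 3, `c1nc2ccc(C3CCCCC3)cc2cc1-c1nn[nH]n1`, has not yet been measured in this assay. It differs from compound 1 by cyclohexyl in place of butyl on an aromatic carbon. Within the data shown here, no measured pair in this set shows what such a change does, so the expectation rests on compound 1 alone. The step that the limit leaves unreadable from compound 1 to compound 3 is expected to stay within the usual scatter, with a fair chance that only a limit is reported again. Compound 3 is therefore estimated at 50 mg/kg, between 10 mg/kg and 200 mg/kg.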

Compound 3, minimum effective dose: > 25 mg/kg
Compound 3: only a limit was reported; the forecaster's own chance of this, stated with the estimate: 70%; the middle value is on the limit's open side.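

Compound 1 and compound 3 both gave only a limit in this assay, and it is the same one: the limit of > 25 mg/kg in this assay, at which 2 of the 3 values shown sit.

No size can therefore be read for the change from butyl to cyclohexyl. From the compounds shown here alone, whether either compound has an effect at a larger dose stays open.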